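The source may hold more compounds than are shown below. What is called first, only, known or untested is meant among the compounds shown, and "the series" means these compounds.

Measured so far:
Compound 1 `C[C@@H](Sc1nc2c(cnn2C)c(=O)n1-c1ccccc1)c1ccccc1` — 34 nM
Compound 2 `COc1cccc(C(C)Sc2nc3c(cnn3C)c(=O)n2-c2ccccc2)c1` — 174 nM

In an assay on isolated protein for inhibition of Retinaldehyde dehydrogenase 3 (Homo sapiens) (a higher number here means a weaker inhibitor, a lower number a stronger inhibitor), compound 2 gives 174 nM, the higher of the two numbers recorded here. For the measured compounds named here, compound 1, the only other compound measured, gives a lower number in this assay, and the gap between the two lies beyond the usual scatter of repeated measurements; nothing more than these two values is known about that pair.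

Compound 3 `CC(Sc1nc2c(cnn2C)c(=O)n1-c1ccccc1)c1cccnc1` has not yet been measured. It differs from compound 2 in a single place: pyridin-3-yl in place of 3-methoxyphenyl on a saturated chain carbon bound to a saturated chain carbon and a sulfur. Going by the values given here, no measured pair shows this exact exchange, so there is no prior step to lean on. Since compound 1 gives 34 nM while compound 2 gives 174 nM, the expectation is that compound 3 moves back toward the lower number, with a step of a 2.2-fold lower number from compound 2 to compound 3 (0.34 log units; beyond the scatter) that is only tentatively beyond the scatter. The estimate for compound 3 in this assay is 80 nM, within a range from 25 nM to 300 nM.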

Compound 3, half-maximal inhibitory concentration: 95 nM
Estimate against measurement, compound 3: 1.2-fold (0.07 log units) below; low and high end bracket the measured number.
By their numbers in this assay, from the lowest: compound 1; then compounds 3 and 2 (each within the scatter of the next).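

In this assay, pyridin-3-yl in place of 3-methoxyphenyl gives a 1.8-fold lower number from compound 2 to compound 3 (0.26 log units; within the scatter) and so leaves these two compounds indistinguishable, even though the exchange removes the methoxy group and puts a nitrogen into the ring. The clearer result comes from the comparison with the unsubstituted phenyl ring, where the change to a pyridine ring gives a 2.8-fold higher number from compound 1 to compound 3 (0.45 log units; beyond the scatter) and compound 1 remains the stronger inhibitor of the pair. No measurement here explains either step.

Compound 1 is drawn as a single mirror-image form at the chain carbon and compound 3 is not. The data do not separate that difference from the change of ring in that step. Also open, on these data alone, is how the position responds to pyridin-4-yl, pyridin-2-yl or a 3-fluorophenyl group.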